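Replacing a dimethylamino side chain with 2-hydroxyethyl

The compounds below may be only part of what the source reports. "The series", "measured", "known", "first", "only" and "open" are said of these compounds alone.

Compound 1 `COc1ccc(C(c2ccc(OC(C)CN(C)C)cc2)c2cccc3ccccc23)c(OC)c1OC` is examined in a functional assay on THP-1 cells (Homo sapiens) for inhibition, read by sulforhodamine B assay, with a stated time of 48 h (a lower number here means a stronger inhibitor, a higher number a weaker inhibitor), where compound 1 gives 15000 nM as its result. Going by the values given here, this is the only true number available so far. Compound 2 `COc1ccc(C(O)(Cc2ccc(C)cc2)c2cccc3ccccc23)c(OC)c1OC` gives > 20000 nM in the same test, and that is a limit of the assay, not a number.

The next compound to be tested is compound 3 `COc1ccc(C(c2ccc(OCCO)cc2)c2cccc3ccccc23)c(OC)c1OC`, which keeps the core of compound 1 and differs in one place: 2-hydroxyethyl in place of 1-((dimethylamino)methyl)ethyl on an oxygen on an aromatic ring is the counted change, with 2-hydroxyethyl in place of 1-((dimethylamino)methyl)ethyl on an oxygen on an aromatic ring.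

Among the compounds with values here, no measured pair shows what this swap does, so any forecast rests on little. Compound 2 also lacks the dimethylamino group and shows > 20000 nM as its limit, which gives no sign of a gain in this assay without that group. The step of a 1.2-fold higher number from compound 1 to compound 3 (0.08 log units; within the scatter) is therefore expected to be small, towards weaker inhibition or within the scatter. The result may also come back as a limit only. For compound 3 the estimated value is 18000 nM within an expected range of 7000 nM to 45000 nM in this test.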

Compound 3, half-maximal inhibitory concentration: 16600 nM
Compound 3: the middle estimate sits 1.1-fold (0.04 log units) above what was measured, and the stated range covers the measured number.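

In this assay, putting 2-hydroxyethyl in place of 1-((dimethylamino)methyl)ethyl on the oxygen gives a 1.1-fold higher number from compound 1 to compound 3 (0.04 log units; within the scatter), so the two results cannot be told apart. Going by these compounds alone, this is the first direct evidence on the side chain: for this pair, the dimethylamino group is not needed to keep the level of inhibition, and a smaller chain ending in a hydroxyl group serves equally well. Compound 3 also returns a true number, whereas compound 2, which differs from compound 1 in more than one place, stops at a limit and not a number: the limit of > 20000 nM in this assay, at which 1 of the 3 values shown sits.

Since two quite different side chains give matching results, the compounds shown do not reveal whether anything placed on this oxygen can move the number in either direction, and both results remain high numbers, meaning weak inhibition. A plain methyl group would show whether the hydroxyl group contributes anything, while a carboxylic acid, a morpholine ring or a longer chain such as 3-hydroxypropyl would test how much this position can accept.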